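The compounds below may be only part of what the source reports. "The series", "measured", "known", "first", "only" and "open" are said of these compounds alone.

Measured in a physicochemical assay for solubility, read by HPLC, in phosphate buffer, at pH 6.8; a lower number here means a less soluble compound, a higher number a more soluble compound:
- compound 1 `CC[C@@H]1CC[C@@H](C(=O)N2CCN(C)CC2)N1C(=O)C1=C(C(C)C)N2C(=N[C@@](C)(c3ccc(Cl)cc3)[C@H]2c2ccc(Cl)cc2)S1`: 13 ug/mL
- compound 2 `CC[C@@H]1CC[C@@H](C(=O)N2CCN(C(C)=O)CC2)N1C(=O)C1=C(C(C)C)N2C(=N[C@@](C)(c3ccc(Cl)cc3)[C@H]2c2ccc(Cl)cc2)S1`: 34 ug/mL
- compound 3 `CC[C@@H]1CC[C@@H](C(=O)N2CCOCC2)N1C(=O)C1=C(C(C)C)N2C(=N[C@@](C)(c3ccc(Cl)cc3)[C@H]2c2ccc(Cl)cc2)S1`: 9 ug/mL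

Compound 3, at 9 ug/mL, cannot be separated from compound 1 on these numbers, with a 1.4-fold lower number from compound 1 to compound 3 (0.16 log units; within the scatter). Compound 2 stands apart from it, with a 3.8-fold lower number from compound 2 to compound 3 (0.58 log units; beyond the scatter).

The next compound is compound 4 `CC[C@@H]1CC[C@@H](C(=O)N2CCN(C)[C@@H](C)C2)N1C(=O)C1=C(C(C)C)N2C(=N[C@@](C)(c3ccc(Cl)cc3)[C@H]2c2ccc(Cl)cc2)S1`, which has not yet been measured. The change is 3,4-dimethylpiperazin-1-yl in place of morpholin-4-yl on a carbonyl carbon.

The step that bears most directly on this is the one between morpholin-4-yl and 4-methylpiperazin-1-yl on the same carbonyl carbon, a 1.4-fold lower number from compound 1 to compound 3 (0.16 log units; within the scatter). Read in reverse, it gives no change beyond the scatter. The two modest steps, a 2.6-fold higher number from compound 1 to compound 2 (0.42 log units; beyond the scatter) and a 3.8-fold lower number from compound 2 to compound 3 (0.58 log units; beyond the scatter), both involve 4-acetylpiperazin-1-yl, which compound 4 does not carry, so they bear on it less. Going by the values given here, no measured compound carries 3,4-dimethylpiperazin-1-yl, and the effect of the added methyl remains untested.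

In this assay, no step beyond the scatter is therefore expected, and the estimate is a 1.4-fold higher number from compound 3 to compound 4 (0.16 log units; within the scatter). The estimated value for compound 4 is 13 ug/mL, with an expected range of 5 ug/mL to 32 ug/mL.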

Compound 4, solubility: 16 ug/mL
Beside the measured number, compound 4's estimate is 1.2-fold (0.09 log units) below it; the range from low to high includes it.
By their numbers in this assay, from the lowest: compounds 3, 1 and 4 (each within the scatter of the next); then compound 2.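

In this assay, the carbonyl carbon tolerates a third group without leaving the scatter: 3,4-dimethylpiperazin-1-yl cannot be separated from morpholin-4-yl (a 1.8-fold higher number from compound 3 to compound 4 (0.25 log units; within the scatter)), and methyl in place of hydrogen on a saturated ring carbon of the 4-methylpiperazin-1-yl group also gives no separable reading (a 1.2-fold higher number from compound 1 to compound 4 (0.09 log units; within the scatter)). The 4-acetylpiperazin-1-yl group also remains distinct from the new group (a 2.1-fold lower number from compound 2 to compound 4 (0.33 log units; beyond the scatter)), so among the four compounds at this position, compound 2 alone is separated from all the others, while the other three form a single group on these numbers. No evidence is available here to account for any of these readings.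

The compounds shown leave open whether the other stereochemical arrangement at the defined stereocentre of 3,4-dimethylpiperazin-1-yl would read the same as compound 4. They also leave open whether the separation of compound 2 extends to other groups on that ring nitrogen, such as methanesulfonyl, a longer acyl chain or a chain ending in a carboxylic acid.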